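A few compounds are considered here, and "the series" means these few. Any claim that something is new, unique, unknown or untested is made for them only; others in the source may bear on it.

Compound 1 `CN(C)CCn1c(=O)c(=Cc2ccc(F)cc2F)s/c1=C1\C(=O)Nc2cc(F)ccc21`: 6460 nM in a functional assay on HT-29 cells (Homo sapiens) for inhibition, read by MTT assay, with a stated time of 72 h; a lower number here means a stronger inhibitor, a higher number a weaker inhibitor
Compound 2 `COc1ccc(C=c2s/c(=C3\C(=O)Nc4cc(F)ccc43)n(CCN(C)C)c2=O)cc1`: 2300 nM
Compound 3 `CN(C)CCn1c(=O)c(=Cc2ccc(C=O)c(C=O)c2)s/c1=C1\C(=O)Nc2cc(F)ccc21`: 1360 nM

All three compounds share one core and differ only in the aromatic group attached to a double-bonded chain carbon bound to an aromatic carbon. Compound 3 has the lowest number of the three. The step of a 4.8-fold lower number from compound 1 to compound 3 (0.68 log units; beyond the scatter) lies beyond the scatter, whereas the step of a 1.7-fold lower number from compound 2 to compound 3 (0.23 log units; within the scatter) lies within the scatter, so compound 3 and compound 2 cannot be told apart on these numbers.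

Compound 4 `COc1ccc(OC)c(C=c2s/c(=C3\C(=O)Nc4cc(F)ccc43)n(CCN(C)C)c2=O)c1` is not yet measured. Relative to compound 3 the change is 2,5-dimethoxyphenyl in place of 3,4-diformylphenyl on a double-bonded chain carbon bound to an aromatic carbon. The measured steps that bear on this are the two exchanges of the aromatic group just described: one modest step when the fluorine-bearing ring of compound 1 was replaced, and one step within the scatter when the single-methoxy ring of compound 2 was replaced. The new group in compound 4 resembles the methoxy-bearing ring of compound 2 more than the diformyl ring of compound 3, so a small rise in the number of compound 4 is expected, though likely within the scatter. In this assay compound 4 is estimated at 2000 nM, with a range from 800 nM to 5000 nM, which means an expected step of a 1.5-fold higher number from compound 3 to compound 4 (0.17 log units; within the scatter).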

Compound 4, half-maximal inhibitory concentration: 4450 nM
Compound 4: the middle estimate sits 2.2-fold (0.35 log units) below what was measured; the measured number falls inside the stated range.
By their numbers in this assay, from the lowest: compounds 3, 2, 4 and 1 (each within the scatter of the next, the first and the last beyond it).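

Exchanging the 3,4-diformylphenyl group for the 2,5-dimethoxyphenyl group on the double-bonded chain carbon gives, in this assay, a 3.3-fold higher number from compound 3 to compound 4 (0.51 log units; beyond the scatter), even though both groups have the same counts of heavy atoms, carbons, oxygens and hydrogen-bond acceptors, so those counts alone do not set the number at this place. The new group cannot be told apart from the two other rings, with a 1.9-fold higher number from compound 2 to compound 4 (0.29 log units; within the scatter) and a 1.5-fold lower number from compound 1 to compound 4 (0.16 log units; within the scatter), although compound 1 and compound 2 do differ beyond the scatter. Compound 3 now stands clear of two compounds, compound 1 and compound 4, but still not of compound 2, so its separation rests on more than one exchange yet does not extend to all of them.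

From the compounds shown here alone, whether a ring carrying a single formyl group, an amine or a carboxylic acid at this place would give a number like that of compound 3 stays open. Nothing measured here accounts for the differences among these four compounds.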